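A few compounds are considered here, and "the series" means these few. Any claim that something is new, unique, unknown or untested is made for them only; others in the source may bear on it.

In a functional assay on PC-3 cells (Homo sapiens) for cytotoxicity, read by WST assay, with a stated time of 24 h (a lower number here means a stronger inhibitor, a higher number a weaker inhibitor), compound 3 `N#C/C(=C\c1c[nH]c2cc(F)ccc12)C(=O)c1c[nH]c2ccccc12` gives > 50000 nM, which is a limit of the assay and not a number. Compound 1 `COc1ccc2c(/C=C(\C#N)C(=O)c3c[nH]c4cc(F)ccc34)c[nH]c2c1` gives > 50000 nM, also a limit. Compound 2 `COc1ccc2c(/C=C(\C#N)C(=O)c3c[nH]c4cc(OC)ccc34)c[nH]c2c1` gives > 50000 nM, again a limit. The readings so far therefore share one ceiling: the limit of > 50000 nM in this assay, at which 3 of the 3 values shown sit.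

Compound 4 `COc1ccc2c(/C=C(\C#N)C(=O)c3c[nH]c4ccccc34)c[nH]c2c1` has not yet been measured. It differs from compound 3 by a single swap, methoxy in place of fluoro on an aromatic carbon. For the measured compounds named here, the only measured step of the same kind is a step that the two limits leave unreadable from compound 1 to compound 2, so it offers no size or direction to carry over. Going by the values given here, with only that step as a guide, no step beyond the usual scatter is expected in this assay, in either direction. The estimated change is a step that the limit leaves unreadable from compound 3 to compound 4. For compound 4 the expected value is 60000 nM, with an estimated range of 30000 nM to 120000 nM, and the assay will most likely report only a limit.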

Compound 4, half-maximal inhibitory concentration: 33300 nM
Estimate against measurement, compound 4: 1.8-fold (0.26 log units) above; low and high end bracket the measured number.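

In this assay, for the compounds shown here, compound 4 is the only one of the four compounds to give a number rather than a limit, so a swap on this aromatic carbon can now be given a direction, though only as a floor: methoxy in place of fluoro gives an at least 1.5-fold lower number from compound 3 to compound 4 (0.17 log units; that floor lies within the scatter). On the other side of the molecule, hydrogen in place of methoxy gives an at least 1.5-fold lower number from compound 2 to compound 4 (0.17 log units; that floor lies within the scatter), and hydrogen in place of fluoro gives an at least 1.5-fold lower number from compound 1 to compound 4 (0.17 log units; that floor lies within the scatter). From the compounds shown here alone, all three floors lie within the scatter, so none proves a real gain, and the true sizes stay unknown since the other compounds give no number: the limit of > 50000 nM in this assay, at which 3 of the 4 values shown sit.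

The step between compound 1 and compound 2 still cannot be read. The compounds shown also leave open how the number would move with an amine or a carboxylic acid on this aromatic carbon.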